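Lipophilicity notes: moving the bromo substituent on the benzyl arm

This account rests on a few compounds, and the source may have more. Where it says the series, first, only, none or still open, it means among the compounds named here.

Compound 1 `CN(C)CCN(CCN(C)C)c1ccc(C(=O)N2CCc3ccc(OS(N)(=O)=O)cc3C2)cc1` sits level with its two measured neighbours in a physicochemical assay for lipophilicity (on this read-out higher numbers stand for higher lipophilicity and lower numbers for lower lipophilicity), giving 1.93. Compound 2 `CCN(Cc1ccc(Br)cc1)c1ccc(C(=O)N2CCc3ccc(OS(N)(=O)=O)cc3C2)cc1` gives 1.93 in this assay, and compound 3 `CCN(Cc1ccc(F)cc1)c1ccc(C(=O)N2CCc3ccc(OS(N)(=O)=O)cc3C2)cc1` gives 1.93. The step from compound 1 to compound 2, no change at the digits printed from compound 1 to compound 2 (within the scatter), and the step from compound 1 to compound 3, no change at the digits printed from compound 1 to compound 3 (within the scatter), both stay within the scatter, as does the step between the two halogen analogues, no change at the digits printed from compound 2 to compound 3 (within the scatter).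

Compound 4 `CCN(Cc1cccc(Br)c1)c1ccc(C(=O)N2CCc3ccc(OS(N)(=O)=O)cc3C2)cc1` is not yet measured. It differs from compound 1 as follows: (3-bromobenzyl)(ethyl)amino in place of bis(2-(dimethylamino)ethyl)amino on an aromatic carbon. Going by the values given here, this is the same kind of exchange as the one from compound 1 to compound 2, with the bromo atom on a different carbon of the benzyl ring; that exchange, no change at the digits printed from compound 1 to compound 2 (within the scatter), produced no movement in this assay beyond the scatter, and neither did the one from compound 1 to compound 3. The step from compound 1 to compound 4 is therefore expected to be no change at the digits printed from compound 1 to compound 4 (within the scatter), no change beyond the scatter. Compound 4 is estimated at 1.93, within a range of 1.55 to 2.35.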

Compound 4, partition coefficient: 1.93
Compound 4: middle estimate and measured number agree at the digits printed; the measured number falls inside the stated range.
By their numbers in this assay, from the lowest: compounds 1, 2, 3 and 4 (each within the scatter of the next).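

Going by these compounds alone, with this assay as the read-out, 3-bromophenyl in place of 4-bromophenyl gives no change at the digits printed from compound 2 to compound 4 (within the scatter) and so adds a comparison the earlier compounds lacked, a change in where the bromo atom sits on the benzyl ring. 3-bromophenyl in place of 4-fluorophenyl, which changes both the halogen and its place, gives no change at the digits printed from compound 3 to compound 4 (within the scatter) as well. The exchange of bis(2-(dimethylamino)ethyl)amino for (3-bromobenzyl)(ethyl)amino gives no change at the digits printed from compound 1 to compound 4 (within the scatter) and so extends the level picture to a third benzyl arm, while no measured evidence bears on the reason for these level values.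

As far as these compounds go, whether a carboxylic acid or a primary amine on the benzyl ring would leave the read-out level stays open. The same holds for a longer chain in place of the ethyl group on the aniline nitrogen.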